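Swapping the chain terminus in a pyridazinone series

The compounds below may be only part of what the source reports. "The series", "measured", "known", "first", "only" and "open" are said of these compounds alone.

Three compounds of this series have been run in a functional assay on the whole organism with Rattus norvegicus as the target; on this read-out higher numbers stand for an effect only at larger amounts of compound and lower numbers for an effect already at smaller amounts. Compound 1 `CC/N=C(/NC#N)NCCCCCn1nc(-c2ccccc2)ccc1=O` gives 60.3 mg/kg, compound 2 `CC/N=C(/NC#N)NCCCCn1nc(-c2ccccc2)ccc1=O` gives 60.7 mg/kg, and compound 3 `N#CNC(=N)NCCCCn1nc(-c2ccccc2)ccc1=O` gives 59.3 mg/kg. Compound 3 has the lowest of the three numbers, but its distance to the other two is within the scatter, so the three stand together. Within the data shown here, the one single-point step, a 1.0-fold lower number from compound 2 to compound 3 (0.01 log units; within the scatter), shows that trimming the terminal group on the amine nitrogen left the read-out unchanged; compound 1 and compound 2, which differ in chain length, likewise give numbers within the scatter of each other.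

Compound 4 `C/N=C(\S)NCCCn1nc(-c2ccccc2)ccc1=O` is not yet measured. It differs from compound 3 in that (a group of 5 heavy atoms (2 carbon, 2 nitrogen, 1 sulfur; no ring) in place of a group of 7 heavy atoms (3 carbon, 4 nitrogen; no ring), on a saturated chain carbon, three bonds along the chain from an aromatic nitrogen). Among the measured compounds shown here, no measured step touches the same end of the molecule in the same way, but the steps seen so far all lie within the scatter, so the author expects a 1.0-fold higher number from compound 3 to compound 4 (0.01 log units; within the scatter), no change beyond the scatter. Compound 4 is therefore estimated at 60 mg/kg, with a range from 30 mg/kg to 120 mg/kg.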

Compound 4, dose for half-maximal effect: 58 mg/kg
For compound 4 the middle estimate is 1.0-fold (0.01 log units) above the measured one, within the range that was stated.
By their numbers in this assay, from the lowest: compounds 4, 3, 1 and 2 (each within the scatter of the next).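

In this assay, the exchange on the saturated chain carbon, three bonds along the chain from an aromatic nitrogen, gives a 1.0-fold lower number from compound 3 to compound 4 (0.01 log units; within the scatter). Unlike the earlier step, which trimmed only a part of the terminal group on an amine nitrogen, this one replaces the group of 7 heavy atoms, with its triple bond, by a group of 5 heavy atoms that brings in sulfur, and still no shift beyond the scatter appears. No measurement at hand says why the read-out holds steady across this exchange.

As far as these compounds go, whether a simple amine or a carboxylic acid at this chain end would move the number beyond the scatter stays open. So does the effect of a chain much longer than that of compound 1, or of any change to the shared core.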